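Fluorophenyl Ureas Without Measurable Cytotoxicity

The source may hold more compounds than are shown below. What is called first, only, known or untested is meant among the compounds shown, and "the series" means these compounds.

Compound 1 `Cc1cc(NC(=O)Nc2ccc(F)cc2)c2ccccc2n1`, compound 2 `Cc1cc(NC(=O)Nc2cccc(F)c2)c2ccccc2n1` and compound 3 `Cc1cc(NC(=O)Nc2cc(F)cc(F)c2)c2ccccc2n1` were tested in an ADME assay on HEK293 cells (Homo sapiens) for cytotoxicity, with a stated time of 72 h; a lower number here means that less compound is needed, a higher number that more compound is needed for the effect. In this assay compound 1 gives > 25000 nM, which is a limit of the assay. Compound 2 gives > 25000 nM, likewise a limit. Compound 3 gives > 25000 nM, also a limit. The step that the two limits leave unreadable from compound 1 to compound 2 and the step that the two limits leave unreadable from compound 2 to compound 3 therefore cannot be sized, as the limit of > 25000 nM in this assay, at which 3 of the 3 values shown sit, shows. The cores of compound 2 and compound 1 differ by 4-fluorophenyl in place of 3-fluorophenyl on an amide-type nitrogen. Compound 4 `Cc1cc(NC(=O)Nc2ccc(F)cc2F)c2ccccc2n1` is not yet measured; it differs from compound 1 by fluoro in place of hydrogen on an aromatic carbon, the same kind of change as fluoro in place of hydrogen on an aromatic carbon, though the place is ortho to a large group rather than meta to a large group. Compound 4 is expected to give 40000 nM in this assay because every shown value sits at the limit of > 25000 nM in this assay, at which 3 of the 3 values shown sit. The expected step is estimated as a step that the limit leaves unreadable from compound 1 to compound 4.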

Compound 4, half-maximal effective concentration: 10000 nM
Estimate against measurement, compound 4: 4.0-fold (0.60 log units) above; measured number below the stated range.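

In this assay, fluoro in place of hydrogen, ortho to a large group and meta to a fluoro group, gives an at least 2.5-fold lower number from compound 1 to compound 4 (0.39 log units; beyond the scatter), so on the core of compound 1 the change at this place has a readable result. Compound 3 carries the same kind of change on the core of compound 2, meta to a large group, and compound 3 gives > 25000 nM, a limit of the assay. The steps among compound 1, compound 2 and compound 3 cannot be read, so the data do not show whether the result carries from one core to another, or whether the place or the core decides it: the limit of > 25000 nM in this assay, at which 3 of the 4 values shown sit.

The compounds shown leave open what fluoro ortho to a large group does on the core of compound 2. They also leave open whether chloro or methoxy at that place gives a step of similar size.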